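Ring change at the aryl carbon: compound 3 outlook

The source may report more compounds than this note shows. Statements on the series, on what has been measured and on what is new or still open speak of the compounds shown alone.

Measured so far in an assay with Cystic fibrosis transmembrane conductance regulator (Rattus norvegicus) as the target; on this read-out higher numbers stand for weaker binding and lower numbers for tighter binding:
compound 1 `COc1cccc(COc2ccccc2C2=NOC(CCl)C2)c1`: 66000 nM
compound 2 `COc1cccc(COc2ccccc2-c2cc(CCO)on2)c1`: 177000 nM

Compound 2 stands at the highest of the two numbers; its nearest neighbour is compound 1, with a 2.7-fold higher number from compound 1 to compound 2 (0.43 log units; beyond the scatter) separating the pair. Compound 3 `COc1cccc(COc2ccccc2C2=NOC(CO)C2)c1` is not yet measured. It differs from compound 2 by a group of 7 heavy atoms (4 carbon, 1 nitrogen, 2 oxygen; one five-membered non-aromatic ring with 2 hetero atoms) in place of a group of 8 heavy atoms (5 carbon, 1 nitrogen, 2 oxygen; one five-membered aromatic ring with 2 hetero atoms), on an aromatic carbon. Among the compounds with values here, only one measured step bears on this change, and it runs the opposite way: going from the five-membered non-aromatic ring of compound 1 to the five-membered aromatic ring of compound 2 gave a 2.7-fold higher number from compound 1 to compound 2 (0.43 log units; beyond the scatter), a modest rise. Within the data shown here, compound 3 returns to a non-aromatic ring, so a lower number of comparable size is expected, with the step estimated as a 2.5-fold lower number from compound 2 to compound 3 (0.40 log units; beyond the scatter), because a 2.7-fold higher number from compound 1 to compound 2 (0.43 log units; beyond the scatter) is the only guide and the added hydroxyl on the ring leaves no measured precedent. Compound 3 is therefore expected to give 70000 nM in this assay, within a range of 25000 nM to 200000 nM.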

Compound 3, dissociation constant: 115000 nM
Compound 3: the middle estimate sits 1.6-fold (0.22 log units) below what was measured; measured number inside the range.
By their numbers in this assay, from the lowest: compounds 1, 3 and 2 (each within the scatter of the next, the first and the last beyond it).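

In this assay the ring exchange on this aromatic carbon gives (a 1.5-fold lower number from compound 2 to compound 3 (0.19 log units; within the scatter)), so compound 2 and compound 3 cannot be told apart on this read-out. Hydroxy in place of chloro on the saturated chain carbon gives (a 1.7-fold higher number from compound 1 to compound 3 (0.24 log units; within the scatter)), so this change also stays inside the scatter, and the step beyond the scatter (a 2.7-fold higher number from compound 1 to compound 2 (0.43 log units; beyond the scatter)) appears only where the two differences are taken together. No measurement on hand gives a reason for these numbers.

From the compounds shown here alone, whether an amine or a carboxylic acid in place of the hydroxy, or a longer chain on the non-aromatic ring, moves the number beyond the scatter remains open. Going by these compounds, the effect of the ring alone also remains open, as the groups of compound 2 and compound 3 differ in more than the ring.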